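This account rests on a few compounds, and the source may have more. Where it says the series, first, only, none or still open, it means among the compounds named here.

In a functional assay on MV4-11 cells (Homo sapiens) for antiproliferative activity, read by luminescence and CellTiter-Glo, with a stated time of 72 h (a lower number here means a stronger inhibitor, a higher number a weaker inhibitor), compound 1 (`CNc1cc(-c2ccc3cnn(Cc4ccc(OC)cc4)c3c2)cn(C)c1=O`) gives 2700 nM and compound 2 (`CNc1cc(-c2ccc3cnn(Cc4ccc(OC)c(F)c4)c3c2)cn(C)c1=O`) gives 4980 nM, so compound 2 stands level with compound 1 within the scatter. Compound 3 (`CNc1cc(-c2ccc3cnn(CC4CC4)c3c2)cn(C)c1=O`) differs from compound 2 by cyclopropyl in place of 3-fluoro-4-methoxyphenyl on a saturated chain carbon bound to an aromatic nitrogen, with cyclopropyl in place of 3-fluoro-4-methoxyphenyl. Within the data shown here, the only measured step, a 1.8-fold higher number from compound 1 to compound 2 (0.27 log units; within the scatter), is just fluoro in place of hydrogen on an aromatic carbon, and it offers little guidance on this replacement. The expected change in this assay is therefore small, estimated as a 1.2-fold higher number from compound 2 to compound 3 (0.08 log units; within the scatter). For compound 3 the expected value is 6000 nM, with an estimated range of 1500 nM to 20000 nM.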

Compound 3, half-maximal inhibitory concentration: 3450 nM
For compound 3 the middle estimate is 1.7-fold (0.24 log units) above the measured one, and the stated range covers the measured number.
By their numbers in this assay, from the lowest: compounds 1, 3 and 2 (each within the scatter of the next).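

In this assay the change at this place, on a saturated chain carbon bound to an aromatic nitrogen, goes beyond a substituent on the phenyl ring: cyclopropyl in place of 3-fluoro-4-methoxyphenyl gives a 1.4-fold lower number from compound 2 to compound 3 (0.16 log units; within the scatter) and cyclopropyl in place of 4-methoxyphenyl gives a 1.3-fold higher number from compound 1 to compound 3 (0.11 log units; within the scatter) so all three compounds stand level. The six-membered aromatic ring and its methoxy group are thus not needed to hold this level here. Nothing available explains this result. The compounds shown leave open whether an amine or a carboxylic acid at this place would shift the number beyond the scatter.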